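Cytotoxicity notes: dimethylamino in place of methyl

A few compounds are considered here, and "the series" means these few. Any claim that something is new, unique, unknown or untested is made for them only; others in the source may bear on it.

The series shares a thiocarbamate core carrying an aryl group, and is followed here in an ADME assay on MT4 cells (Homo sapiens) for cytotoxicity, read by MTT assay; on this read-out higher numbers stand for lower toxicity in this test and lower numbers for higher toxicity in this test. Within the data shown here, compound 2 `Cc1ccc(NC(=S)OCCc2ccccn2)cc1` gives 75000 nM, the only number among the three values shown. Compound 1 `Cc1cccc(NC(=S)OCCc2ccccn2)c1` reaches only the limit of the assay, > 100000 nM. Compound 3 `Fc1ccc(NC(=S)OCCc2ccccn2)cc1` likewise reaches only the limit, > 100000 nM. Among the measured compounds shown here, the one step that can be described, an at least 1.3-fold higher number from compound 2 to compound 3 (0.12 log units; that floor lies within the scatter), has a floor that lies within the scatter, and the limit of > 100000 nM in this assay, at which 2 of the 3 values shown sit, shows how little the measured values separate.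

Compound 4 `CN(C)c1ccc(NC(=S)OCCc2ccccn2)cc1` differs from compound 2 by dimethylamino in place of methyl on an aromatic carbon. For the measured compounds named here, no measured step changes this position in the same way, so the step with fluoro in place of methyl on an aromatic carbon is the only guide, and it gives no size beyond the scatter. Compound 4 is therefore expected to sit near compound 2, with a 1.2-fold higher number from compound 2 to compound 4 (0.08 log units; within the scatter). The estimate for compound 4 is 90000 nM, with a range from 40000 nM to 200000 nM, and a fair chance that the assay again reports only its limit.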

Compound 4, half-maximal cytotoxic concentration: 60000 nM
Beside the measured number, compound 4's estimate is 1.5-fold (0.18 log units) above it; low and high end bracket the measured number.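

In this assay, dimethylamino in place of methyl on an aromatic carbon, para to a large group, gives a 1.3-fold lower number from compound 2 to compound 4 (0.10 log units; within the scatter), so a larger group with a hydrogen-bond acceptor and a nitrogen can enter here without a step beyond the scatter. Among these compounds, compound 4 also gives this position a second actual number rather than another limit, and that number cannot be told apart from the one for compound 2. The comparison with the fluoro compound gives an at least 1.6-fold lower number from compound 3 to compound 4 (0.22 log units; that floor lies within the scatter), which is only a floor, so no order can be set among methyl, dimethylamino and fluoro at this position: the limit of > 100000 nM in this assay, at which 2 of the 4 values shown sit.

Going by these compounds, whether any group at this position moves the number beyond the scatter remains open, for instance a carboxylic acid, a primary amine or a longer chain in place of methyl. Also open, on these data alone, is whether dimethylamino gives a similar result at the ring position that carries methyl in compound 1, and whether changes to the shared core away from the aryl group matter more than this substituent does.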